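Replacing 3-hydroxyphenyl with ((3-chlorophenyl)carbamoyl)amino

This account rests on a few compounds, and the source may have more. Where it says the series, first, only, none or still open, it means among the compounds named here.

In a functional assay on CCRF-CEM cells (Homo sapiens) for inhibition, read by MTT assay, with a stated time of 72 h (a lower number here means a stronger inhibitor, a higher number a weaker inhibitor), compound 1 (`COc1cc(NC(C)CCCNC(=O)Nc2cccc(O)c2)c2ncccc2c1`) gives 32000 nM. Compound 2 (`COc1cc(NC(C)CCCNC(=O)Nc2cc(C(F)(F)F)cc(C(F)(F)F)c2)c2ncccc2c1`) gives 4100 nM, which leaves compound 1 with the higher of the two numbers, by a gap beyond the scatter. Compound 3 (`COc1cc(NC(C)CCCNC(=O)NNC(=O)Nc2cccc(Cl)c2)c2ncccc2c1`) keeps the core of compound 1 and differs from it as follows: ((3-chlorophenyl)carbamoyl)amino in place of 3-hydroxyphenyl on an amide-type nitrogen. Going by the values given here, no measured step covers this change, so the only guide is the lower number of compound 2 at 4100 nM. A moderate step of a 2.9-fold lower number from compound 1 to compound 3 (0.46 log units; beyond the scatter) is expected in this assay, towards a lower number. Compound 3 is estimated at 11000 nM, with an expected range of 3500 nM to 35000 nM.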

Compound 3, half-maximal inhibitory concentration: 81000 nM
Estimate against measurement, compound 3: 7.4-fold (0.87 log units) below; measured number outside the range, above it.
By their numbers in this assay, from the lowest: compound 2; then compound 1; then compound 3.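

In this assay, placing ((3-chlorophenyl)carbamoyl)amino in place of 3-hydroxyphenyl on the amide-type nitrogen gives a 2.5-fold higher number from compound 1 to compound 3 (0.40 log units; beyond the scatter) and so weakens inhibition. At this position, then, a group with more heavy atoms and an added carbonyl does not bring a stronger inhibitor. Nothing available accounts for this loss. On these data alone, the chlorine, the ring substituent and the added carbamoyl-amino link all change together, so their separate contributions remain open. As far as these compounds go, it is also open how 3-chlorophenyl or 3-aminophenyl would read directly on that nitrogen.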